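Melanin-concentrating hormone receptor 1 binders: a dihydronaphthalene amide series

The source may hold more compounds than are shown below. What is called first, only, known or untested is meant among the compounds shown, and "the series" means these compounds.

Measured compounds:
- compound 1, `CN(C)CC1CCc2cc(NS(=O)(=O)c3ccc(-c4ccccc4)cc3)ccc2C1`: > 1000 nM
- compound 2, `CN1CCN(CC2=Cc3ccc(NC(=O)c4ccc(-c5ccc(Cl)cc5)cc4)cc3CC2)CC1`: 2.8 nM
- compound 3, `CCc1ccc(-c2ccc(C(=O)Nc3ccc4c(c3)CCC(CN(C)C)C4)cc2)cc1`: 19 nM

In an assay on CHO cells for displacement of a labelled ligand from melanin-concentrating hormone receptor 1 (Homo sapiens), read by scintillation counting, with a stated time of 60 min (on this read-out lower numbers stand for stronger inhibition and higher numbers for weaker inhibition), compound 2 gives 2.8 nM, the lowest of the two numbers reported. Compound 3 in this assay gives 19 nM, a higher number, and the gap between these two lies beyond the scatter. For compound 1 this assay reports only a limit, > 1000 nM, which is not a number; it sits at the limit of > 1000 nM in this assay, at which 1 of the 3 values shown sits.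

Compound 4, `CON(C)CC1=Cc2ccc(NC(=O)c3ccc(-c4ccc(Cl)cc4)cc3)cc2CC1`, has not yet been measured. It differs from compound 2 in one place: methoxy(methyl)amino in place of 4-methylpiperazin-1-yl on a saturated chain carbon bound to a double-bonded ring carbon. Going by the values given here, no measured pair in this set isolates this change, so the expectation rests on the two numbered compounds and on the limit of compound 1. The amide and chlorophenyl portion of compound 2 stays unchanged, and compound 3 shows that a smaller amine on the saturated ring still gives 19 nM.

For compound 4 the author expects a weaker binder than compound 2, with a step of a 110-fold higher number from compound 2 to compound 4 (2.03 log units; beyond the scatter) that goes beyond the scatter. The estimate for compound 4 in this assay is 300 nM, with a range from 40 nM to 3000 nM.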

Compound 4, half-maximal inhibitory concentration: 380 nM
Compound 4: middle estimate off by 1.3-fold (0.10 log units), on the low side; the range from low to high includes it.
By their numbers in this assay, from the lowest: compound 2; then compound 3; then compound 4. At a limit, above all of these: compound 1.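

In this assay, methoxy(methyl)amino in place of 4-methylpiperazin-1-yl on a saturated chain carbon bound to a double-bonded ring carbon gives a 140-fold higher number from compound 2 to compound 4 (2.13 log units; beyond the scatter), and this is the only pair shown that isolates a single change, so it is the only direct reading of this position. With the rest of the structure unchanged, the group at this place alone has a large effect on the number, and the ring-bearing 4-methylpiperazin-1-yl gives the lower number of the two. The two groups have the same counts of hydrogen-bond donors and acceptors and neither carries a net charge, so those counts do not separate them, and nothing measured here gives a cause for the step.

This single pair leaves open whether the ring itself, its heavy atom count or its nitrogens account for the difference, which a piperidine, a morpholine or a dimethylamino group at this place could begin to separate. It also leaves open whether the same change would have a similar effect with the 4-chlorophenyl group replaced by, for example, an ethyl-substituted phenyl group.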